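Chloro on the benzylsulfanyl group, carried across two cores

This account rests on a few compounds, and the source may have more. Where it says the series, first, only, none or still open, it means among the compounds named here.

Compound 1 `COc1ccc(C2N=C(SCc3ccccc3)NC(C)=C2C(=O)Nc2ccc(F)cc2)cc1OC` carries an unsubstituted benzylsulfanyl group. In a functional assay on the whole organism (artery, strain albino) with Rattus norvegicus as the target, with a stated time of 360 min, at a dose of 10 mg/kg by the oral route (a lower number here means less inhibition, a higher number more inhibition at the dose given (going by the name of the read-out)), compound 1 gives 3.6%. Compound 2 `COc1ccc(C2N=C(SCc3ccccc3Cl)NC(C)=C2C(=O)Nc2ccc(F)cc2)cc1OC` differs from it by chloro in place of hydrogen on an aromatic carbon, and in this assay compound 2 gives 39.2%; the step is a number 35.6 percentage points higher from compound 1 to compound 2 (beyond the scatter). Compound 3 `CC1=C(C(=O)Nc2ccc(Br)cc2)C(c2ccc(Cl)cc2Cl)N=C(SCc2ccccc2)N1` is built on a second core; the difference between the two cores is not broken down here. In this assay compound 3 gives 24.2%, the second highest of the three measured numbers, beyond the scatter from both of the others. Compound 4 `CC1=C(C(=O)Nc2ccc(Br)cc2)C(c2ccc(Cl)cc2Cl)N=C(SCc2ccccc2Cl)N1` has not been measured; it differs from compound 3 by chloro in place of hydrogen on an aromatic carbon, the same change as that made from compound 1 to compound 2, here on the second core, so the change occurs twice among the compounds shown. Going by the values given here, only one measured instance of it exists, on one core, so its transfer is uncertain. The step from compound 3 to compound 4 in this assay is expected to be a number 25.8 percentage points higher from compound 3 to compound 4 (beyond the scatter), kept smaller than a number 35.6 percentage points higher from compound 1 to compound 2 (beyond the scatter) given the single observation and the higher start of compound 3 at 24.2%. For compound 4 in this assay the estimate is 50%, with a range from 28% to 72%.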

Compound 4, a percentage reported as inhibition, in the whole organism at one dose (the size of the read-out at that dose, not a potency): 38.1%
Estimate against measurement, compound 4: 11.9 percentage points above, and the stated range covers the measured number.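

Carried to the second core, chloro in place of hydrogen on an aromatic carbon again raises the number in this assay, with a number 13.9 percentage points higher from compound 3 to compound 4 (beyond the scatter). The direction therefore repeats on both cores, but the size of the step does not carry over: the same change on two cores in this assay, a number 35.6 percentage points higher (beyond the scatter) from compound 1 to compound 2 and a number 13.9 percentage points higher (beyond the scatter) from compound 3 to compound 4, 21.7 percentage points apart, beyond the scatter of two such steps. Two pairs cannot show which part of the cores sets the size, since the cores differ in more than one place, and they give no rule for any further core.

The compounds shown hold only hydrogen or chloro at this place on the benzyl group, so it stays open whether the gain is particular to chloro or would also appear with a nitrile or an amine there. On these data alone, since the read-out comes from a single dose and a single stated time, it also stays open whether the gap between the two steps would persist under other conditions.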